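Phenyl for thiophene on a ribosylated bicyclic core

The source may report more compounds than this note shows. Statements on the series, on what has been measured and on what is new or still open speak of the compounds shown alone.

Of the compounds shown here, three of this set have been measured in an ADME assay on BJ cells (Homo sapiens), read by MTT assay, with a stated time of 72 h; a lower number here means a stronger inhibitor, a higher number a weaker inhibitor. Compound 1 `Cc1nc(N)c2c(-c3ccccc3)cn([C@@H]3O[C@H](CO)[C@@H](O)[C@H]3O)c2n1` and compound 2 `Cc1nc(N)c2c(-c3cccs3)cn([C@@H]3O[C@H](CO)[C@@H](O)[C@H]3O)c2n1` share one core, while compound 3 `COc1ncnc2c1c(-c1cccs1)cn2[C@@H]1O[C@H](CO)[C@@H](O)[C@H]1O` carries a methoxy-bearing core; the difference between the two cores is not broken down here. Compound 1 gives only a limit in this assay, > 100000 nM. Compound 2 likewise gives only a limit, > 100000 nM. Within the data shown here, compound 3 is the single compound with a number, 62800 nM.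

The change from compound 2 to compound 1 is phenyl in place of thiophen-2-yl on an aromatic carbon, and the step that the two limits leave unreadable from compound 2 to compound 1 cannot be read, since both ends sit at the limit of > 100000 nM in this assay, at which 2 of the 3 values shown sit. The unmeasured compound 4 `COc1ncnc2c1c(-c1ccccc1)cn2[C@@H]1O[C@H](CO)[C@@H](O)[C@H]1O` arises from compound 3 by the same change, (phenyl in place of thiophen-2-yl on an aromatic carbon).

For compound 4 this account therefore expects a value of 80000 nM in this assay, with a range from 30000 nM to 250000 nM. The estimated step this implies is a 1.3-fold higher number from compound 3 to compound 4 (0.11 log units; within the scatter). The expectation is kept close to compound 3 at 62800 nM. It stays there because a step that the two limits leave unreadable from compound 2 to compound 1 gives no readable direction for the exchange. With compound 3 already lying near (the limit of > 100000 nM in this assay, at which 2 of the 3 values shown sit), there is a fair chance that compound 4 is reported only as a limit.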

Compound 4, half-maximal inhibitory concentration: > 100000 nM
Compound 4 ended at the assay's limit; the forecaster's own chance of this, stated with the estimate: 45%; at least 1.2-fold (0.09 log units) between middle value and limit.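

In this assay, the exchange of thiophen-2-yl for phenyl on the core of compound 3 gives an at least 1.5-fold higher number from compound 3 to compound 4 (0.20 log units; that floor lies within the scatter), so only a lower bound on the step can be read, and that bound alone does not set the two compounds apart. On the shared core of compound 1 and compound 2, the same exchange cannot be read, which leaves a single step of partly readable size in this series and no test of whether the change carries from one core to another. What the compounds do show is how much of this small set stands at the end of the measurable range, so that a further phenyl or thiophen-2-yl exchange may yield little more than another limit: the limit of > 100000 nM in this assay, at which 3 of the 4 values shown sit.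

The compounds shown leave open whether another group on the same aromatic carbon, such as a pyridine ring, a carboxylic acid or a longer alkyl chain, would give a number clearly apart from the limit. They also leave open what the methoxy group alone contributes, as no pair shown differs only in the core.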